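The compounds below may be only part of what the source reports. "The series", "measured", "known", "first", "only" and "open" are said of these compounds alone.

Compound 2 `CCCCCCn1c(Cc2cc(OC)c(OC)c(OC)c2)nc2c(N)nc(F)nc21` gives 112000000 nM in a functional assay on MCF7 cells (Homo sapiens) for cytotoxicity; a higher number here means that more compound is needed for the effect, a lower number that less compound is needed. Going by the values given here, of the two numbers measured, compound 2 has the lower one, but its only neighbour, compound 1 `CCCCn1c(Cc2cc(OC)c(OC)c(OC)c2)nc2c(N)nc(F)nc21`, lies within the scatter of it: compound 1 gives 185000000 nM in this assay, and the change a 1.7-fold lower number from compound 1 to compound 2 (0.22 log units; within the scatter) does not rise above the usual spread of repeated measurements.

Compound 3 `COCCCn1c(Cc2cc(OC)c(OC)c(OC)c2)nc2c(N)nc(F)nc21` differs from compound 2 in a single place: methoxy in place of propyl on a saturated chain carbon, three bonds along the chain from an aromatic nitrogen. Among the compounds with values here, the one step measured so far concerns a different change, ethyl in place of hydrogen on a saturated chain carbon four bonds along the chain from an aromatic nitrogen, and that step was within the scatter. Within the data shown here, no measured step covers a methoxy entering in place of propyl, so nothing in the two values points toward a shift of any size in this assay for compound 3. The expectation for compound 3 is therefore a step of a 1.2-fold higher number from compound 2 to compound 3 (0.06 log units; within the scatter), that is, no shift beyond the scatter. On that basis compound 3 is estimated at 130000000 nM in this assay, with a range from 45000000 nM to 380000000 nM.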

Compound 3, half-maximal effective concentration: 72600000 nM
The estimate for compound 3 lay 1.8-fold (0.25 log units) above the measured number, and the stated range covers the measured number.
By their numbers in this assay, from the lowest: compounds 3, 2 and 1 (each within the scatter of the next, the first and the last beyond it).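

In this assay, methoxy in place of propyl on a saturated chain carbon, three bonds along the chain from an aromatic nitrogen, gives a 1.5-fold lower number from compound 2 to compound 3 (0.19 log units; within the scatter) and so does not separate 3-methoxypropyl from hexyl at this position. Methoxy in place of methyl at the same place gives a 2.5-fold lower number from compound 1 to compound 3 (0.41 log units; beyond the scatter) and is the only step among these compounds that lies beyond the scatter, although it is modest; this position therefore tolerates an oxygen-bearing chain without any loss in this assay, and the comparison with compound 1 gives the series its first readable difference. No measurement here bears on why the chain with methoxy sits where it does.

Going by these compounds, what remains open is whether a hydroxyl or an amine at this place would give a step of similar size or a larger one, and whether a carboxylic acid would hold the number near that of compound 3. On these data alone, it is also open whether a longer chain ending in methoxy would stay within the scatter of compound 3 in this assay or move beyond it.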